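Compound 2 to compound 4: a fluoro step

A few compounds are considered here, and "the series" means these few. Any claim that something is new, unique, unknown or untested is made for them only; others in the source may bear on it.

Compound 2 (`Clc1cccc2sc(Nc3nc4ccccc4s3)nc12`) reads > 50000 nM in a functional assay on U-937 cells (Homo sapiens) for cytotoxicity, read by MTT assay, with a stated time of 48 h (on this read-out higher numbers stand for weaker inhibition and lower numbers for stronger inhibition), and this is a limit of the assay, not a number. Compound 2 therefore stands at the limit of > 50000 nM in this assay, at which 1 of the 3 values shown sits. Compound 3 (`c1ccc2sc(Nc3nc4ccccc4s3)nc2c1`) gives 40000 nM in this assay. For the measured compounds named here, the one measured step is hydrogen in place of chloro on an aromatic carbon, an at least 1.2-fold lower number from compound 2 to compound 3 (0.09 log units; that floor lies within the scatter). Compound 1 (`Fc1ccc2nc(NC(=S)Nc3ccc(Cl)cc3)sc2c1`) also carries a fluoro group but differs elsewhere, and it gives 18700 nM. Going by the values given here, no step connects it to compound 4, so it sets no step size here.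

Compound 4 (`Fc1ccc2nc(Nc3nc4c(Cl)cccc4s3)sc2c1`) follows from compound 2 by fluoro in place of hydrogen on an aromatic carbon. Among the compounds with values here, no measured step shows this exchange. Within the data shown here, the only guide is the small step to compound 3, an at least 1.2-fold lower number from compound 2 to compound 3 (0.09 log units; that floor lies within the scatter), so no change beyond the scatter is expected in this assay. The estimated step is an at least 1.2-fold lower number from compound 2 to compound 4 (0.09 log units; that floor lies within the scatter). For compound 4 the expected value is 40000 nM, with an estimated range of 15000 nM to 70000 nM.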

Compound 4, half-maximal inhibitory concentration: 50000 nM
Beside the measured number, compound 4's estimate is 1.3-fold (0.10 log units) below it; the measured number falls inside the stated range.
By their numbers in this assay, from the lowest: compound 1; then compounds 3 and 4 (each within the scatter of the next).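

In this assay compound 4 gives 50000 nM, so fluoro in place of hydrogen on this aromatic carbon, with the chloro group kept, yields a measured number rather than a limit. Compound 2 stands only at a limit of the assay, not at a number: the limit of > 50000 nM in this assay, at which 1 of the 4 values shown sits. For the compounds shown here, the step reads a number no higher from compound 2 to compound 4 (the limit leaves the size open) and so the fluoro exchange has no size in this pair.

Still open, as far as these compounds go, is how an amine or a methoxy group on this same aromatic carbon would read in this assay. Also open, from the compounds shown here alone, is whether fluoro in place of hydrogen gives a readable step on the core of compound 3, which has a number of its own at 40000 nM.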